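This account rests on a few compounds, and the source may have more. Where it says the series, first, only, none or still open, it means among the compounds named here.

Compound 1, `CCC(C)COc1cccc2ccc(N)nc12`, is the point of departure. In an assay on cells with melanin-concentrating hormone receptor 1 (Homo sapiens) as the target, read by radioligand binding (a lower number here means a stronger inhibitor, a higher number a weaker inhibitor), compound 1 gives 36 nM, the lowest of the two numbers in hand. Compound 2, `CCC(CC)C(C)Oc1cccc2ccc(N)nc12`, gives 191 nM in this assay, a gap that lies beyond the scatter. Compound 3, `CC(CC(C)(C)C)Oc1cccc2ccc(N(C)C)nc12`, reaches only a limit in this assay, > 2000 nM, and the limit of > 2000 nM in this assay, at which 1 of the 3 values shown sits, marks it as a limit rather than a number. No pair among these three differs in one place only, so no single step has been measured.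

Compound 4, `CC1CCC(Oc2cccc3ccc(N)nc23)C1`, is the next structure to be tested in this assay. It differs from compound 1 by 3-methylcyclopentyl in place of 2-methylbutyl on an oxygen on an aromatic ring. Since the two compounds that carry a larger group on that oxygen than compound 1 give weaker numbers, compound 4 is expected to sit somewhat weaker than compound 1, with an expected step of a 1.8-fold higher number from compound 1 to compound 4 (0.26 log units; within the scatter), which may well fall inside the usual scatter. Compound 4 is therefore estimated at 65 nM, within a range from 20 nM to 220 nM.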

Compound 4, half-maximal inhibitory concentration: 823 nM
Estimate against measurement, compound 4: 13-fold (1.10 log units) below, and the stated range ends below it.
By their numbers in this assay, from the lowest: compound 1; then compound 2; then compound 4. At a limit, above all of these: compound 3.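

In this assay, putting 3-methylcyclopentyl in place of 2-methylbutyl on the oxygen on an aromatic ring gives a 23-fold higher number from compound 1 to compound 4 (1.36 log units; beyond the scatter), the first single change measured at this position. It shows that the number at this position can move far beyond the scatter with this one exchange of carbon-only groups, neither of which carries a hydrogen-bond donor or acceptor. This single step cannot separate the effect of the five-membered ring from that of the longer count of heavy atoms, and nothing measured here bears on the cause of the step.

On these data alone, it remains open whether plain cyclopentyl, or a chain ending in an amine, would keep the number of compound 1 at 36 nM. Within the data shown here, it also remains open how a change elsewhere on the core of compound 1 would act, since this is the only single step in hand.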